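The source may report more compounds than this note shows. Statements on the series, on what has been measured and on what is new or still open speak of the compounds shown alone.

Measured compounds:
compound 1, `Cc1nc(N)sc1CCCN/C(N)=N/C(=O)NCc1ccco1` — 0.58
compound 2, `Cc1nc(N)sc1CCCN/C(N)=N/C(=S)N[C@@H](C)c1ccccc1` — 0.65
compound 3, `Cc1nc(N)sc1CCCN/C(N)=N/C(=O)NC(C)c1ccc(OC(F)(F)F)cc1` — 0.61

All three were tested in a functional assay on Right cardiac atrium for agonist activity at histamine H2 receptor (Cavia porcellus), with a stated time of 30 min, in the presence of a further agent that is not named here; on this read-out higher numbers stand for larger maximal responses and lower numbers for smaller maximal responses. On this read-out compound 1 gives 0.58, the smallest of the three numbers, yet the nearest value, that of compound 3 at 0.61, and the furthest, that of compound 2 at 0.65, both lie within the usual scatter of it, so the three compounds cannot be told apart on these numbers.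

The next compound, compound 4, `Cc1nc(N)sc1CCCN/C(N)=N/C(=O)NC(C)c1ccco1`, is a close relative of compound 1. The difference between the two is methyl in place of hydrogen on a saturated chain carbon bound to an amide-type nitrogen and an aromatic carbon. Everything else in the molecule, including the shared core, is kept as it stands in compound 1.

Among the measured compounds shown here, no pair among the measured compounds differs in this place alone, so there is no measured step to lean on. Given that the three measured values sit so close to one another, the expectation is that compound 4 will stay in the same region, with a step from compound 1 to compound 4 of a number 0.020 higher from compound 1 to compound 4 (within the scatter), that is, none beyond the scatter in either direction. The estimate for compound 4 in this assay is 0.6, with a range from 0.48 to 0.72.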

Compound 4, intrinsic activity: the largest response reached, as a fraction of the reference agonist's: 1
Estimate against measurement, compound 4: 0.40 below, outside the stated range (above it).
By their numbers in this assay, from the lowest: compounds 1, 3 and 2 (each within the scatter of the next); then compound 4.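

In this assay, adding a single methyl group on the saturated chain carbon bound to an amide-type nitrogen and an aromatic carbon, which turns (furan-2-yl)methyl into 1-(furan-2-yl)ethyl, gives a number 0.42 higher from compound 1 to compound 4 (beyond the scatter). Among the compounds shown here, this position therefore matters for the size of the maximal response: the earlier compounds offered no measured step here, yet this one added carbon, which brings no ring, hydrogen-bond donor or hydrogen-bond acceptor, clearly separates the pair, and compound 4, at 1, reaches the full response of the reference agonist. Nothing available here explains why so small a structural change has so large an effect.

On these data alone, it remains open whether this rise is particular to methyl, since an ethyl group, a longer chain or an amine on the same carbon could keep it, shrink it or reverse it. For the compounds shown here, it is also open whether the same methyl would have a similar effect in other compounds, as this single pair, both members of which carry the furan-2-yl group, is the only measured example of the step.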